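This account rests on a few compounds, and the source may have more. Where it says the series, first, only, none or still open, it means among the compounds named here.

In a functional assay on MCF7 cells (Homo sapiens) for inhibition, read by CCK-8 assay, with a stated time of 48 h (a higher number here means a weaker inhibitor, a lower number a stronger inhibitor), compound 1 (`COc1cc(-c2ccnc3cc(-c4ccc(Cl)cc4)nn23)cc(OC)c1OC`) gives 2320 nM. Compound 2 (`COc1cc(-c2ccnc3cc(-c4cccc(C#N)c4)nn23)cc(OC)c1OC`) gives > 10000 nM, which is a limit and not a number. Compound 3 (`COc1cc(-c2ccnc3cc(-c4cn(C)c5ccccc45)nn23)cc(OC)c1OC`) differs from compound 2 by 1-methyl-1H-indol-3-yl in place of 3-cyanophenyl on an aromatic carbon, with 1-methyl-1H-indol-3-yl in place of 3-cyanophenyl. Within the data shown here, one measured step bears on this change: an at least 4.3-fold higher number from compound 1 to compound 2 (0.63 log units; beyond the scatter), at the same aromatic carbon and beyond the scatter. Since compound 2 stands at a limit, a clear move to a lower number in this assay is expected. The expected step is an at least 25-fold lower number from compound 2 to compound 3 (1.39 log units; beyond the scatter). For compound 3 the estimate is 400 nM, with an expected range of 40 nM to 4000 nM.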

Compound 3, half-maximal inhibitory concentration: 95 nM
Compound 3: middle estimate off by 4.2-fold (0.62 log units), on the high side, within the range that was stated.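

At this aromatic carbon the earlier pair showed only a move to a higher number, whereas 1-methyl-1H-indol-3-yl shows that the same place can also carry a large gain in this assay, with a 24-fold lower number from compound 1 to compound 3 (1.39 log units; beyond the scatter) and an at least 100-fold lower number from compound 2 to compound 3 (2.02 log units; beyond the scatter). Compound 2 holds a limit and not a number, so the step from it gives a bound and no exact size: the limit of > 10000 nM in this assay, at which 1 of the 3 values shown sits.

Open, as far as these compounds go, is how much of the gain rests on the methyl group of 1-methyl-1H-indol-3-yl. Also open, from the compounds shown here alone, is whether unmethylated 1H-indol-3-yl or a benzothiophene at this carbon would keep the gain.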